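A few compounds are considered here, and "the series" means these few. Any claim that something is new, unique, unknown or untested is made for them only; others in the source may bear on it.

Measured compounds in a functional assay on SMMC-7721 cells (Homo sapiens) for antiproliferative activity, read by MTT assay, with a stated time of 48 h; a higher number here means a weaker inhibitor, a lower number a stronger inhibitor:
Compound 1 `Cn1cc(C2=C(c3nn(CCCN4CCCCC4)c4ncccc34)C(=O)N(c3ccccn3)C2=O)c2ccccc21` gives > 100000 nM, which is a limit of the assay.
Compound 2 `Cn1cc(C2=C(c3nn(CCCCn4ccnc4)c4ncccc34)C(=O)NC2=O)c2ccccc21` gives 29200 nM.
Compound 3 `Cn1cc(C2=C(c3nn(CCCn4ccnc4)c4ncccc34)C(=O)NC2=O)c2ccccc21` gives > 100000 nM, also a limit of the assay.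

Compound 1 thus stands at the limit, (the limit of > 100000 nM in this assay, at which 2 of the 3 values shown sit), and carries no number of its own. Compound 4 `Cn1cc(C2=C(c3nn(CCCN4CCCCC4)c4ncccc34)C(=O)N(c3cccc4ccccc34)C2=O)c2ccccc21` differs from it by naphthalen-1-yl in place of pyridin-2-yl on an amide-type nitrogen in a ring. Among the measured compounds shown here, the only measured step, an at least 3.4-fold higher number from compound 2 to compound 3 (0.53 log units; beyond the scatter), concerns the chain on the aromatic nitrogen and not the amide-type nitrogen in the ring, so no measured step bears on the change from compound 1 to compound 4. For compound 4 in this assay the expected step is therefore a number no higher from compound 1 to compound 4 (the limit leaves the size open), none beyond the scatter. Compound 4 is estimated at 100000 nM, with a range from 30000 nM to 300000 nM, most probably reported again only as a limit.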

Compound 4, half-maximal inhibitory concentration: 220 nM
Compound 4: middle estimate off by 450-fold (2.66 log units), on the high side, outside the stated range (below it).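

In this assay, among the compounds shown here, the amide-type nitrogen in the ring, which no earlier step touched, proves a decisive position: naphthalen-1-yl in place of pyridin-2-yl gives an at least 450-fold lower number from compound 1 to compound 4 (2.65 log units; beyond the scatter). The chain with the piperidine ring is therefore compatible with strong activity when this group is present. Compound 1 is a limit of the assay, so this step remains a bound because compound 1 has no number of its own: the limit of > 100000 nM in this assay, at which 2 of the 4 values shown sit.

Phenyl or quinolinyl on this nitrogen would help separate the second ring from the loss of the ring nitrogen. On these data alone, whether naphthalen-1-yl has a similar effect with the imidazole chains of compound 2 and compound 3 remains open.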